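Varying the aryl on the ethenyl chain: compounds 1 to 4

The compounds below may be only part of what the source reports. "The series", "measured", "known", "first", "only" and "open" are said of these compounds alone.

Three compounds of the series have numbers in a functional assay on DU-145 cells (Homo sapiens) for cytotoxicity, read by MTT assay, with a stated time of 72 h; a lower number here means a stronger inhibitor, a higher number a weaker inhibitor. Compound 1 `COc1cc(C(=O)c2cc(OC)c(OC)c(OC)c2)cc(NC(=O)/C=C/c2cc(OC)c(OC)c(OC)c2)c1OC` gives 6600 nM. Compound 2 `COc1ccc(/C=C/C(=O)Nc2cc(C(=O)c3cc(OC)c(OC)c(OC)c3)cc(OC)c2OC)cc1N` gives 12700 nM. Compound 3 `C#CCOc1cccc(/C=C/C(=O)Nc2cc(C(=O)c3cc(OC)c(OC)c(OC)c3)cc(OC)c2OC)c1` gives 13500 nM, the highest number of the three; its nearest neighbour is compound 2, with a 1.1-fold higher number from compound 2 to compound 3 (0.03 log units; within the scatter), and the furthest is compound 1, with a 2.0-fold higher number from compound 1 to compound 3 (0.31 log units; beyond the scatter). Within the data shown here, the aryl on the double-bonded chain carbon is the only place that changes across these three, and the whole spread is about one step beyond the scatter.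

Compound 4 `COc1cc(C(=O)c2cc(OC)c(OC)c(OC)c2)cc(NC(=O)/C=C/c2cc(F)c(F)c(F)c2)c1OC` continues at the same place: 3,4,5-trifluorophenyl in place of 3-(propargyloxy)phenyl on a double-bonded chain carbon bound to a double-bonded chain carbon. Among the measured compounds shown here, no measured step exchanges an aryl bearing only fluorine, so the step cannot be read off directly. What bears on it is that the two exchanges at this position, from compound 1 to compound 3 and from compound 2 to compound 3, moved the number by at most a modest amount, and that the amount from compound 1 to compound 2 was within the scatter. On that basis a step of modest size at most, in either direction, is expected; the estimate sits near the measured cluster. Compound 4 is expected to give 10000 nM, in a range from 3500 nM to 30000 nM. That estimate means an expected step of a 1.4-fold lower number from compound 3 to compound 4 (0.13 log units; within the scatter).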

Compound 4, half-maximal inhibitory concentration: 7900 nM
For compound 4 the middle estimate is 1.3-fold (0.10 log units) above the measured one; low and high end bracket the measured number.
By their numbers in this assay, from the lowest: compounds 1, 4, 2 and 3 (each within the scatter of the next, the first and the last beyond it).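

In this assay the 3,4,5-trifluorophenyl group gives a 1.7-fold lower number from compound 3 to compound 4 (0.23 log units; within the scatter) and a 1.6-fold lower number from compound 2 to compound 4 (0.21 log units; within the scatter) and also a 1.2-fold higher number from compound 1 to compound 4 (0.08 log units; within the scatter) with each of these steps within the scatter. The earlier compounds shown here all carry oxygen or nitrogen on this aryl, whereas compound 4 has only fluorine there and no hydrogen-bond acceptor in the group, so neither oxygen nor nitrogen on the ring is needed for a number of this size on a double-bonded chain carbon bound to a double-bonded chain carbon. Nothing at hand accounts for these steps or says why this position tolerates such different aryls.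

The compounds shown leave open whether any aryl at this place can separate clearly from the cluster, since the only step beyond the scatter remains the one between compound 1 and compound 3, and compound 4 lies within the scatter of both. Also open, on these data alone, is how far the position stretches beyond these substituted phenyl groups, for instance to an unsubstituted phenyl, a carboxylic acid on the ring, a dimethylamino group or a cyclohexyl ring in place of the aryl.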